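The source may hold more compounds than are shown below. What is called first, only, known or untested is meant among the compounds shown, and "the series" means these compounds.

Compound 1 `NC1(CCn2ccc(=O)[nH]c2=O)OC(=O)C(OCc2ccccc2)=C1OCc1ccccc1` is one of three compounds whose inhibition has been measured in an ADME assay on WI-38 cells (Homo sapiens) for inhibition, read by MTT assay, with a stated time of 72 h; a higher number here means a weaker inhibitor, a lower number a stronger inhibitor. In this assay compound 1 gives only a limit of the assay, > 100000 nM, and not a number. Compound 2 `O=C1O[C@H]([C@@H](O)Cn2c(=O)[nH]c(=O)[nH]c2=O)C(OCc2ccccc2)=C1OCc1ccccc1` likewise gives only a limit in this assay, > 100000 nM. Compound 3 `O=C1O/C(=C\Cn2ncc(=O)[nH]c2=O)C(OCc2ccccc2)=C1OCc1ccccc1` gives a number in this assay, 24600 nM. Going by the values given here, compound 1 therefore stands at the limit of > 100000 nM in this assay, at which 2 of the 3 values shown sit, so no step between measured compounds can be drawn from it. Compound 4 `Cc1cn(CCC2(N)OC(=O)C(OCc3ccccc3)=C2OCc2ccccc2)c(=O)[nH]c1=O` differs from compound 1 by methyl in place of hydrogen on an aromatic carbon. In this assay no step beyond the usual scatter is expected from this change, in either direction. Compound 4 is expected to give about 100000 nM, between 50000 nM and 300000 nM. The expected step is a number no higher from compound 1 to compound 4 (the limit leaves the size open), and most likely only a limit will again be reported.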

Compound 4, half-maximal inhibitory concentration: > 100000 nM
Compound 4: a limit, no number; the forecaster's own chance of this, stated with the estimate: 80%; the middle value sits exactly at the limit.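

Going by these compounds alone, compound 1 and compound 4 both give only a limit in this assay, not a number, so no step between them can be read: the limit of > 100000 nM in this assay, at which 3 of the 4 values shown sit. As far as these compounds go, whether methyl in place of hydrogen on an aromatic carbon changes the inhibition at all stays open.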